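The compounds below may be only part of what the source reports. "The series", "measured", "known", "first", "only" and "open" are said of these compounds alone.

Three compounds share one core and have been run in a functional assay on isolated protein for agonist activity at Glucose-dependent insulinotropic receptor (Rattus norvegicus), read by HTRF and cAMP accumulation; a higher number here means a larger maximal response, a lower number a smaller maximal response. Compound 1 `Cc1nc(S(C)(=O)=O)ccc1O[C@H]1CC[C@H](OC2CCN(C(=O)OC(C)C)CC2)CC1` gives 114% in this assay. Compound 2 `CC(C)(C)OC(=O)N1CCC(O[C@H]2CC[C@H](Oc3ccc(S(C)(=O)=O)nn3)CC2)CC1` gives 86% in this assay. Compound 3 `C[C@H](CF)OC(=O)N1CCC(O[C@H]2CC[C@H](Oc3cnc(S(C)(=O)=O)cn3)CC2)CC1` gives 115% in this assay, the largest of the three numbers; compound 1 sits within the usual scatter of it, while compound 2 sits clearly lower, beyond the scatter. No pair among these three differs in just one place, so no single structural step can be tied to a change in the numbers.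

Compound 4 `CC(F)Cc1nc(CN2CCC(O[C@H]3CC[C@H](Oc4cnc(S(C)(=O)=O)cn4)CC3)CC2)no1` has not yet been measured in this assay. It differs from compound 3 in one place: a group of 10 heavy atoms (6 carbon, 2 nitrogen, 1 oxygen, 1 fluorine; one five-membered aromatic ring with 3 hetero atoms) in place of a group of 7 heavy atoms (4 carbon, 2 oxygen, 1 fluorine; no ring), on an amine nitrogen in a ring. The part of the molecule that carries the aromatic core and its six-membered ring bearing the methylsulfonyl group is the same in compound 3 and compound 4.

Among the compounds with values here, with no measured step of this kind to lean on, the expectation for compound 4 rests on the narrow spread of the three numbers so far, and the step from compound 3 to compound 4 is expected to be small, a number 10 percentage points lower from compound 3 to compound 4 (within the scatter), with no clear direction beyond the scatter. For compound 4 in this assay the estimate is 105%, in a range from 80% to 125%.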

Compound 4, largest response reached (Emax), in percent of the reference or control that the assay uses: 114%
Estimate against measurement, compound 4: 9 percentage points below, within the range that was stated.
By their numbers in this assay, from the lowest: compound 2; then compounds 1, 4 and 3 (each within the scatter of the next).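

In this assay, within the data shown here, the first single-place step at this position reads a number 1 percentage points lower from compound 3 to compound 4 (within the scatter), which lies within the scatter. The amine nitrogen in the six-membered non-aromatic ring can therefore carry either the open-chain group of compound 3 or the (5-(2-fluoropropyl)-1,2,4-oxadiazol-3-yl)methyl group of compound 4, which has 10 heavy atoms and a five-membered aromatic ring, with no clear difference in maximal response; in this one pair, the double bond outside aromatic rings in the group that leaves is not needed to keep that response. No measurement shown here explains why the two groups match.

On these data alone, this is a single pair on a single core, so it remains open whether the same holds for quite different groups on that nitrogen, such as a plain methyl, a benzyl or a chain ending in a carboxylic acid. As far as these compounds go, it is also open what the fluorine contributes, which a plain propyl chain on the same five-membered ring would test.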